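This account rests on a few compounds, and the source may have more. Where it says the series, first, only, none or still open, it means among the compounds named here.

Within the data shown here, compound 2, `O=S(=O)(Nc1ccccc1NS(=O)(=O)c1cccc(Cl)c1)c1cccc(Cl)c1`, stands at the lower of the two numbers so far in an assay for binding affinity to protein lin-28 homolog A (Mus musculus), with a stated time of 1 h (on this read-out lower numbers stand for stronger inhibition and higher numbers for weaker inhibition), giving 5700 nM; compound 1, `O=S(=O)(Nc1ccccc1NS(=O)(=O)c1cccc(Cl)c1)c1ccc(F)cc1`, gives 10800 nM, and the step of a 1.9-fold lower number from compound 1 to compound 2 (0.28 log units; within the scatter) is a 3-chlorophenyl in place of 4-fluorophenyl on a sulfonyl sulfur. Compound 3, `Cc1ccc(NS(=O)(=O)c2cccc(Cl)c2)c(NS(=O)(=O)c2cccc(Cl)c2)c1`, differs from compound 2 by methyl in place of hydrogen on an aromatic carbon, on the shared core, meta to a large group and para to a large group. Among the measured compounds shown here, no measured step touches that position, and the one known step lies within the scatter, so in this assay compound 3 is expected to sit close to compound 2, at 5000 nM with a range of 2000 nM to 14000 nM, a step of a 1.1-fold lower number from compound 2 to compound 3 (0.06 log units; within the scatter).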

Compound 3, half-maximal inhibitory concentration: 4300 nM
The estimate for compound 3 lay 1.2-fold (0.07 log units) above the measured number; the range from low to high includes it.
By their numbers in this assay, from the lowest: compounds 3, 2 and 1 (each within the scatter of the next, the first and the last beyond it).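

Methyl in place of hydrogen on this aromatic carbon of the shared core, meta to a large group and para to a large group, is the first change shown at this position, and in this assay the step is a 1.3-fold lower number from compound 2 to compound 3 (0.12 log units; within the scatter). The position therefore takes a methyl without a step beyond the scatter. Among these compounds, no evidence on these compounds bears on this result. As far as these compounds go, whether an amine, a carboxylic acid or a longer chain on this carbon would give a step beyond the scatter stays open, as does the effect of methyl elsewhere on the shared core.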